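The compounds below may be only part of what the source reports. "The series", "measured", "known", "first", "only" and "open" are said of these compounds alone.

Of the compounds shown here, three of one shared core have been tested in a functional assay on NCI-H1975 cells (Homo sapiens) for antiproliferative activity, read by MTT assay, with a stated time of 72 h; a higher number here means a weaker inhibitor, a lower number a stronger inhibitor. Compound 3 `COc1cc2ncnc(Nc3cccc(Cl)c3F)c2cc1OCCCCC(=O)Nc1ccc(S(N)(=O)=O)cc1` gives 6930 nM, the lowest of the two real numbers shown. Compound 1 `COc1cc2ncnc(Nc3cccc(Br)c3)c2cc1OCCCCC(=O)Nc1ccc(S(N)(=O)=O)cc1` gives 11400 nM, and the step of a 1.6-fold lower number from compound 1 to compound 3 (0.22 log units; within the scatter) stays within the scatter. Compound 2 `COc1cc2ncnc(Nc3ccc(F)cc3)c2cc1OCCCCC(=O)Nc1ccc(S(N)(=O)=O)cc1` gives > 40000 nM, which is a limit of the assay and not a number (the limit of > 40000 nM in this assay, at which 1 of the 3 values shown sits). The steps of an at least 3.5-fold higher number from compound 1 to compound 2 (0.54 log units; beyond the scatter) and an at least 5.7-fold lower number from compound 2 to compound 3 (0.76 log units; beyond the scatter) show that the 4-fluorophenyl group weakened the activity beyond the scatter, while the bromine and chlorine-bearing groups did not differ from each other.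

Compound 4 `COc1cc2ncnc(Nc3cc(F)c(F)c(F)c3)c2cc1OCCCCC(=O)Nc1ccc(S(N)(=O)=O)cc1` is not yet measured. The change is 3,4,5-trifluorophenyl in place of 3-chloro-2-fluorophenyl on a nitrogen on an aromatic ring. The incoming group carries only fluorine, as the 4-fluorophenyl of compound 2 does, and drops the chlorine. Since compound 2 reached only a limit, > 40000 nM, a weaker result than compound 3 is expected, with the step of a 2.9-fold higher number from compound 3 to compound 4 (0.46 log units; beyond the scatter) in this assay. Compound 4 is therefore expected to give about 20000 nM, within a range from 7000 nM to 60000 nM.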

Compound 4, half-maximal inhibitory concentration: 20000 nM
Compound 4: middle estimate and measured number agree at the digits printed; low and high end bracket the measured number.
By their numbers in this assay, from the lowest: compounds 3, 1 and 4 (each within the scatter of the next, the first and the last beyond it). At a limit, above all of these: compound 2.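

In this assay, a 2.9-fold higher number from compound 3 to compound 4 (0.46 log units; beyond the scatter) shows that the 3,4,5-trifluorophenyl group on this nitrogen gives up a modest amount against 3-chloro-2-fluorophenyl, while a 1.8-fold higher number from compound 1 to compound 4 (0.24 log units; within the scatter) leaves it not separable from 3-bromophenyl. This change also shows that a group carrying only fluorine can still return a real number here, and an at least 2.0-fold lower number from compound 2 to compound 4 (0.30 log units; that floor lies within the scatter) gives a floor too small to set compound 4 clearly apart from compound 2. The reading for compound 2 is a limit and not a number: the limit of > 40000 nM in this assay, at which 1 of the 4 values shown sits.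

On these data alone, what a 3-chlorophenyl group, or a phenyl bearing a nitrile or a trifluoromethyl, would give on this nitrogen stays open. So does the effect of a shorter or longer chain between the shared core and the amide.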